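Extending the alkyl chain of compound 2 by one more carbon

A few compounds are considered here, and "the series" means these few. Any claim that something is new, unique, unknown or untested is made for them only; others in the source may bear on it.

Three chloromethyl ketones sharing one core were measured in a functional assay on NALM-6 cells (Homo sapiens); a higher number here means a weaker inhibitor, a lower number a stronger inhibitor. Compound 1 `CCSC[C@H](NC(C)=O)C(=O)CCl` gives 52800 nM. Compound 2 `CCCCCCCCSC[C@H](NC(C)=O)C(=O)CCl` gives 5600 nM, and compound 3 `CCCCCCCCCCCCCCSC[C@H](NC(C)=O)C(=O)CCl` gives 8700 nM. Compound 2 is separated from compound 1 by a 9.4-fold lower number from compound 1 to compound 2 (0.97 log units; beyond the scatter), a step beyond the scatter, whereas the step of a 1.6-fold higher number from compound 2 to compound 3 (0.19 log units; within the scatter) stays within it, so compound 2 and compound 3 cannot be told apart on these numbers.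

Compound 4 `CCCCCCCCCCCCCCCSC[C@H](NC(C)=O)C(=O)CCl` is not yet measured. It differs from compound 2 by heptyl in place of hydrogen on a saturated chain carbon, eight bonds along the chain from a sulfur. Going by the values given here, the one step that bears directly on this change is a 1.6-fold higher number from compound 2 to compound 3 (0.19 log units; within the scatter), where hexyl entered at the same place and the number did not move beyond the scatter; the larger step from compound 1 to compound 2 concerns a different place on the chain and is not a guide here. He therefore expects no change beyond the scatter, worded as a 1.5-fold higher number from compound 2 to compound 4 (0.18 log units; within the scatter). His estimate for compound 4 in this assay is 8500 nM, with a range from 4000 nM to 18000 nM.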

Compound 4, half-maximal inhibitory concentration: 8900 nM
Estimate against measurement, compound 4: 1.0-fold (0.02 log units) below; measured number inside the range.
By their numbers in this assay, from the lowest: compounds 2, 3 and 4 (each within the scatter of the next); then compound 1.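

At this place on the chain, this assay now gives a second long-chain comparison: heptyl in place of hydrogen gives a 1.6-fold higher number from compound 2 to compound 4 (0.20 log units; within the scatter) and stays within the scatter, as the hexyl step did. The further methyl adds a finer test, with a 1.0-fold higher number from compound 3 to compound 4 (0.01 log units; within the scatter) also within the scatter, so compound 2, compound 3 and compound 4 cannot be told apart on these numbers. The three compounds therefore show no measurable difference across these chain lengths, and this holds for single-carbon as well as multi-carbon changes at the positions tested.

The compounds shown leave open whether a longer chain, or an amine or a carboxylic acid on a saturated chain carbon, eight bonds along the chain from a sulfur, would separate from compound 2 in this read-out. No supporting measurement accompanies this result that could explain it.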